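The source may report more compounds than this note shows. Statements on the series, on what has been measured and on what is new or still open speak of the compounds shown alone.

Working notes on the series.

Going by the values given here, compound 1 `CCCn1cc(COc2cc(O)c3c(c2)O[C@H](c2ccc(OC)c(O)c2)CC3=O)nn1` is the only member of this set with a ketone core and a propyl group on the aromatic nitrogen; in a functional assay on RAW264.7 cells (Mus musculus) for inhibition, read by Griess assay, with stated times of 2 h and 24 h (on this read-out lower numbers stand for stronger inhibition and higher numbers for weaker inhibition), compound 1 gives 9670 nM. Two further compounds carry an oxime in place of the ketone: compound 2 `COc1ccc([C@@H]2C/C(=N\O)c3c(O)cc(OCc4cn(Cc5ccccc5F)nn4)cc3O2)cc1O` with a 2-fluorobenzyl group, which in this assay gives 5710 nM, and compound 3 `COc1ccc([C@@H]2C/C(=N\O)c3c(O)cc(OCc4cn(C5CCCC5)nn4)cc3O2)cc1O` with a cyclopentyl group, which in this assay gives 6880 nM. Against these numbers compound 1 stands highest, but its gap to compound 3 and its gap to compound 2 are both within the scatter, so the three values cannot be ordered.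

Compound 4 `COc1ccc([C@@H]2CC(=O)c3c(O)cc(OCc4cn(Cc5ccc(Cl)cc5)nn4)cc3O2)cc1O` keeps the ketone core of compound 1 and differs from it in one place: 4-chlorophenyl in place of ethyl on a saturated chain carbon bound to an aromatic nitrogen. Among the compounds with values here, the only measured step that touches the group on the aromatic nitrogen is a 1.2-fold higher number from compound 2 to compound 3 (0.08 log units; within the scatter), which is within the scatter; it is measured on the oxime core, not on the ketone, and it does not cover a propyl group at all. Within the data shown here, no measured step therefore predicts a change beyond the scatter.

The step of a 1.3-fold lower number from compound 1 to compound 4 (0.11 log units; within the scatter) is what the estimate assumes, a movement no larger than the scatter. Compound 4 is expected to give about 7500 nM, with a range from 3000 nM to 18000 nM.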

Compound 4, half-maximal inhibitory concentration: 17800 nM
Compound 4: the middle estimate sits 2.4-fold (0.38 log units) below what was measured; measured number inside the range.
By their numbers in this assay, from the lowest: compounds 2, 3, 1 and 4 (each within the scatter of the next, the first and the last beyond it).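

In this assay, going by these compounds alone, the change from propyl to 4-chlorobenzyl, which brings in a six-membered aromatic ring of carbon and a chlorine, gives a 1.8-fold higher number from compound 1 to compound 4 (0.26 log units; within the scatter) and is the only step at this position on the ketone core. Set beside a 1.2-fold higher number from compound 2 to compound 3 (0.08 log units; within the scatter) on the oxime core, it shows that both steps read at this position stay within the scatter, on either core and for this larger change from a plain chain to a chlorine-bearing benzyl group. No measurement at hand bears on why the number responds to this change as it does.

From the compounds shown here alone, what the oxime does in place of the ketone with the same group on the aromatic nitrogen stays open, as each oxime here carries a different group from each ketone. Also open, going by these compounds, is whether a group of another kind at this place, such as an amine, a carboxylic acid or a longer chain, would move the number beyond the scatter.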